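Benzyl substituent swap on the thienopyridine amide series

The source may hold more compounds than are shown below. What is called first, only, known or untested is meant among the compounds shown, and "the series" means these compounds.

Within the data shown here, compound 2 `NC(=O)c1c(NC(=O)c2ccccc2Cl)sc2c1CCN(Cc1ccccc1Cl)C2` gives 4430 nM in a functional assay on MKN-74 cells (Homo sapiens) for antiproliferative activity, with a stated time of 24 h (on this read-out higher numbers stand for weaker inhibition and lower numbers for stronger inhibition), the lowest of the two numbers measured so far. Among the measured compounds shown here, its nearest neighbour is compound 1 `N#Cc1ccccc1CN1CCc2c(sc(NC(=O)c3ccccc3Cl)c2C(N)=O)C1`, which gives 9500 nM in this assay; the step of a 2.1-fold lower number from compound 1 to compound 2 (0.33 log units; beyond the scatter) is the only measured step and concerns the same benzyl aromatic ring that is altered next.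

Compound 3 `NC(=O)c1c(NC(=O)c2ccccc2Cl)sc2c1CCN(Cc1ccc([N+](=O)[O-])cc1)C2` is not yet measured. Relative to compound 2 it carries 4-nitrophenyl in place of 2-chlorophenyl on a saturated chain carbon bound to an amine nitrogen in a ring, so both the group and its position on that ring differ from compound 2. The step from compound 1 to compound 2 shows that exchanging the group on this ring moves the number only modestly, and that the 2-chlorophenyl form sits at the lower number. For the measured compounds named here, with no measured 4-nitrophenyl analogue, a small step back towards the number of compound 1 is expected, or none beyond the scatter, and the expected step is a 1.8-fold higher number from compound 2 to compound 3 (0.26 log units; within the scatter). Compound 3 is estimated at 8000 nM in this assay, with a range from 3000 nM to 25000 nM.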

Compound 3, half-maximal inhibitory concentration: 31500 nM
Beside the measured number, compound 3's estimate is 3.9-fold (0.60 log units) below it, and the stated range ends below it.
By their numbers in this assay, from the lowest: compound 2; then compound 1; then compound 3.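

In this assay, the benzyl ring proves more sensitive than the first swap suggested: against a 2.1-fold lower number from compound 1 to compound 2 (0.33 log units; beyond the scatter), the 4-nitrobenzyl form gives a 7.1-fold higher number from compound 2 to compound 3 (0.85 log units; beyond the scatter) and a 3.3-fold higher number from compound 1 to compound 3 (0.52 log units; beyond the scatter), which makes compound 3 the weakest of the three, with both steps beyond the scatter. The 2-chlorophenyl and 2-cyanophenyl forms both stay at lower numbers than the 4-nitrophenyl form, so the substituent on this ring can shift the read-out further than the earlier pair showed, though in this series only in the direction of weaker inhibition. Nothing available bears on why the number rises with this change.

Group and ring position change together between compound 2 and compound 3, so the compounds shown cannot say which of the two carries the step; a nitro group placed where compound 2 holds its chlorine, or a chlorine placed where compound 3 holds its nitro group, would separate them. Also open, going by these compounds, is how an unsubstituted benzyl group, or an amine or a carboxylic acid on this ring, would read against these three numbers.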